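This account rests on a few compounds, and the source may have more. Where it says the series, first, only, none or still open, it means among the compounds named here.

Working notes on the series. In a functional assay on OVCAR-4 cells (Homo sapiens) for antiproliferative activity, read by sulforhodamine B assay, with a stated time of 48 h (on this read-out lower numbers stand for stronger inhibition and higher numbers for weaker inhibition), compound 1 (`O=C(NCCCNc1cc(-c2cn(-c3ccccc3)nc2-c2cccc(O)c2)ccn1)Nc1ccc(F)cc1`) gives 1460 nM and compound 2 (`O=C(NCCCNc1cc(-c2cn(-c3ccccc3)nc2-c2cccc(O)c2)ccn1)Nc1cccc(C(F)(F)F)c1`) gives 2130 nM. Going by the values given here, these two numbers are not separated: a 1.5-fold higher number from compound 1 to compound 2 (0.16 log units; within the scatter) lies within the scatter, so compound 1 stands level with the only other measured compound.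

Compound 3 (`COc1cccc(-c2nn(-c3ccccc3)cc2-c2ccnc(NCCCNC(=O)Nc3ccc(F)cc3)c2)c1`) has not yet been measured in this assay. It differs from compound 1 in one place: methyl in place of hydrogen on an oxygen on an aromatic ring, which reads as hydroxy to methoxy, or 3-hydroxyphenyl to 3-methoxyphenyl.

Among the compounds with values here, no measured step touches that oxygen. Within the data shown here, the one available step, a 1.5-fold higher number from compound 1 to compound 2 (0.16 log units; within the scatter), replaces 4-fluorophenyl with 3-(trifluoromethyl)phenyl on an amide-type nitrogen, a different place from this change. It offers only weak guidance on size and none on direction. The expectation in this assay is therefore no step beyond the scatter, with a slight lean towards a higher number that is a judgement and not a measured trend. The starting point is compound 1 at 1460 nM.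

The estimated step is a 1.4-fold higher number from compound 1 to compound 3 (0.14 log units; within the scatter). For compound 3 the expected value is 2000 nM, with an estimated range of 800 nM to 5500 nM.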

Compound 3, half-maximal inhibitory concentration: 10500 nM
Compound 3: middle estimate off by 5.3-fold (0.72 log units), on the low side; the measured number lies above the stated range.
By their numbers in this assay, from the lowest: compounds 1 and 2 (each within the scatter of the next); then compound 3.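

The oxygen on the 3-hydroxyphenyl ring is a sensitive position in this assay: methyl in place of hydrogen there gives a 7.2-fold higher number from compound 1 to compound 3 (0.86 log units; beyond the scatter) and so moves the read-out beyond the scatter. Going by these compounds alone, the only earlier step, a 1.5-fold higher number from compound 1 to compound 2 (0.16 log units; within the scatter), changed the aryl group on the amide-type nitrogen and stayed within the scatter, so the earlier compounds gave no sign that any part of the series could move the number this far. For this one pair, the free hydroxy form carries the lower number, but no supporting data bear on why the number rises with methoxy.

Going by these compounds, the step rests on a single pair with 4-fluorophenyl on the amide-type nitrogen, so whether methoxy costs as much alongside the 3-(trifluoromethyl)phenyl group of compound 2 remains open. The compounds shown also leave open how this position responds to other groups, such as an ethoxy, an amine or a carboxylic acid in place of the hydroxy, and so whether the hydrogen itself or the size of the added group sets the read-out.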